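The source may hold more compounds than are shown below. What is called first, only, known or untested is meant among the compounds shown, and "the series" means these compounds.

In an assay on HEK-293T cells for inhibition of diacylglycerol lipase-alpha (Homo sapiens), read by colorimetric assay (on this read-out higher numbers stand for weaker inhibition and lower numbers for stronger inhibition), two compounds built on one shared core have been measured so far. Compound 1 `O=Cc1coc(C(=O)CCCCCCc2ccccc2)n1` gives 1510 nM in this assay. Compound 2 `O=C(CCCCCCc1ccccc1)c1nc(Cl)co1` gives 2400 nM in this assay. The only structural difference between them is chloro in place of formyl on an aromatic carbon, and the step of a 1.6-fold higher number from compound 1 to compound 2 (0.20 log units; within the scatter) lies within the scatter of repeated measurements, so on these numbers the two compounds cannot be told apart. Compound 3 `CN(C)C(=O)c1coc(C(=O)CCCCCCc2ccccc2)n1` has not yet been measured. It differs from compound 2 by dimethylcarbamoyl in place of chloro on an aromatic carbon. Among the compounds with values here, no measured step involves dimethylcarbamoyl, and the one comparison available, from formyl to chloro at this same aromatic carbon, did not move the number beyond the scatter. A further exchange at that carbon is therefore expected to leave the number close to that of compound 2, with no step beyond the scatter in either direction, although a single comparison cannot rule out a shift. The expected step is a 1.2-fold lower number from compound 2 to compound 3 (0.08 log units; within the scatter). Compound 3 is estimated at 2000 nM, with a range from 600 nM to 7000 nM.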

Compound 3, half-maximal inhibitory concentration: 3390 nM
Estimate against measurement, compound 3: 1.7-fold (0.23 log units) below; the measured number falls inside the stated range.
By their numbers in this assay, from the lowest: compounds 1, 2 and 3 (each within the scatter of the next, the first and the last beyond it).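

In this assay, putting dimethylcarbamoyl in place of chloro on the aromatic carbon next to the ring nitrogen brings in five heavy atoms where there was one, including a hydrogen-bond acceptor, yet the result is a 1.4-fold higher number from compound 2 to compound 3 (0.15 log units; within the scatter) and so compounds 2 and 3 cannot be told apart. Within the data shown here, this same position also gives the first step beyond the scatter: dimethylamino in place of hydrogen on the carbonyl carbon of the formyl group gives a 2.2-fold higher number from compound 1 to compound 3 (0.35 log units; beyond the scatter) and this remains a modest step. Formyl, chloro and dimethylcarbamoyl at this carbon therefore differ greatly in size as counted in heavy atoms, while the numbers stay fairly close, with only compounds 1 and 3 separated beyond the scatter.

No measurement shown here explains why these numbers fall as they do. From the compounds shown here alone, it also remains open whether a carboxylic acid or a primary amine at this carbon would move the number further, and whether these exchanges would give similar steps with a shorter chain in the large group on the ring.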